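Two Hydroxyls for One on the Side Chain

The compounds below may be only part of what the source reports. "The series", "measured", "known", "first", "only" and "open" are said of these compounds alone.

Both measured compounds share the same brominated core and differ only in the chain that hangs from the aromatic nitrogen. Compound 1 `OC(CCn1nc2c(Br)c(Br)c(Br)c(Br)c2n1)c1ccc(F)cc1` carries a chain bearing a hydroxyl and an aromatic ring, and compound 2 `C[C@H](O)CCn1nc2c(Br)c(Br)c(Br)c(Br)c2n1` carries a 3-hydroxybutyl chain. In a functional assay on CCRF-CEM cells (Homo sapiens) for antiproliferative activity, read by MTT assay, with a stated time of 24 h, tested at 50 uM (on this read-out lower numbers stand for a stronger effect and higher numbers for a weaker effect at the one concentration tested), compound 1 gives 46%, while compound 2 gives 86%. Compound 2 therefore stands highest of the two numbers, and its gap to compound 1 lies beyond the usual scatter, so compound 1 shows the stronger effect of the pair.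

Compound 3 `OCC(O)Cn1nc2c(Br)c(Br)c(Br)c(Br)c2n1` has not yet been measured. It differs from compound 2 in one place: 1,2-dihydroxyethyl in place of 2-hydroxypropyl on a saturated chain carbon bound to an aromatic nitrogen. Among the compounds with values here, no measured pair shows this change, so there is no earlier step to lean on, and the core is unchanged. No step beyond the scatter is expected, and the change from compound 2 to compound 3 is estimated as a number 4 percentage points lower from compound 2 to compound 3 (within the scatter). In this assay compound 3 is expected to give about 82%, with a likely range from 62% to 100%.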

Compound 3, a percentage reported as activity, at one concentration (the size of the read-out at that concentration, not a potency): 47%
Compound 3: the middle estimate sits 35 percentage points above what was measured; the whole stated range lies above it.
By their numbers in this assay, from the lowest: compounds 1 and 3 (each within the scatter of the next); then compound 2.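

In this assay, putting 1,2-dihydroxyethyl in place of 2-hydroxypropyl on a saturated chain carbon bound to an aromatic nitrogen gives a number 39 percentage points lower from compound 2 to compound 3 (beyond the scatter), so this position responds strongly to a change that leaves the number of heavy atoms in the group the same. The earlier compounds shown here also left it possible that the aromatic ring on the chain of compound 1 was needed for a reading near that level, yet compound 3 has no ring on its chain and gives 47%, within the scatter of compound 1 at 46%. Nothing measured here explains why this small change has so large an effect.

The step combines two changes, an added hydroxyl and the loss of the one defined stereocentre, and these compounds cannot separate them. On these data alone, it also remains open how this assay would read with an amine or a carboxylic acid in place of the second hydroxyl, or with a longer chain carrying both hydroxyls.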